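Five-membered ring swaps on the shared core of compound 1

The source may hold more compounds than are shown below. What is called first, only, known or untested is meant among the compounds shown, and "the series" means these compounds.

Measured compounds:
compound 1, `CC(C)C(Cc1ncc[nH]1)c1ccc(-c2ccc3cccc(F)c3c2)[nH]c1=O`, 11 nM
compound 2, `CC(C)C(c1cnc(N)s1)c1ccc(-c2ccc3cccc(F)c3c2)[nH]c1=O`, 16 nM
compound 3, `CC(C)C(Cc1noc(=O)[nH]1)c1ccc(-c2ccc3cccc(F)c3c2)[nH]c1=O`, 34 nM

The values come from an assay on CHO cells for displacement of a labelled ligand from prostaglandin E2 receptor EP3 subtype (Homo sapiens), read by radioligand binding; on this read-out higher numbers stand for weaker inhibition and lower numbers for stronger inhibition. Compound 1 stands lowest of the three numbers, though its nearest neighbour, compound 2, sits within the scatter: a 1.5-fold higher number from compound 1 to compound 2 (0.16 log units; within the scatter). The furthest is compound 3, with a 3.1-fold higher number from compound 1 to compound 3 (0.49 log units; beyond the scatter). Between the other two, a 2.1-fold higher number from compound 2 to compound 3 (0.33 log units; beyond the scatter).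

The unmeasured compound is compound 4, `CC(C)C(Cc1nnn[nH]1)c1ccc(-c2ccc3cccc(F)c3c2)[nH]c1=O`. It differs from compound 1 by 1H-tetrazol-5-yl in place of 1H-imidazol-2-yl on a saturated chain carbon, two bonds along the chain from an aromatic carbon.

Within the data shown here, the step that bears most directly on this change is the one from compound 1 to compound 3, where the five-membered ring on the same chain carbon was exchanged for another five-membered ring richer in hetero atoms, and the result was a modest weakening. The step from compound 1 to compound 2, which alters the chain as well as the ring, was within the scatter. On this basis a modest weakening is expected for compound 4, of about the size seen toward compound 3, and that expectation reads a 2.3-fold higher number from compound 1 to compound 4 (0.36 log units; beyond the scatter). Compound 4 is therefore estimated at 25 nM, with a range from 10 nM to 70 nM.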

Compound 4, inhibition constant: 34 nM
The estimate for compound 4 lay 1.4-fold (0.13 log units) below the measured number; measured number inside the range.
By their numbers in this assay, from the lowest: compounds 1 and 2 (each within the scatter of the next); then compounds 3 and 4 (each within the scatter of the next).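

In this assay, the 1H-tetrazol-5-yl group on this saturated chain carbon, two bonds along the chain from an aromatic carbon, gives a 3.1-fold higher number from compound 1 to compound 4 (0.49 log units; beyond the scatter), so a second ring with more hetero atoms than 1H-imidazol-2-yl also moves the number up, by a step of the same printed size as a 3.1-fold higher number from compound 1 to compound 3 (0.49 log units; beyond the scatter). The two replacements cannot be told apart in this assay, with no change at the digits printed from compound 3 to compound 4 (within the scatter), and among the three compounds carrying a ring at this place, none goes against the pattern that both richer rings read above the 1H-imidazol-2-yl ring; the step of a 2.1-fold higher number from compound 2 to compound 4 (0.33 log units; beyond the scatter) further shows that the 1H-tetrazol-5-yl compound also stands clear of the aminothiazole compound, which compound 1 does not. No measurement is available here that would explain this shift.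

The compounds shown leave open how a carboxylic acid or a 1,2,4-triazol-3-yl ring would read at this place, and so whether the number follows the count of hetero atoms at all. They also leave open whether a longer chain carrying the 1H-tetrazol-5-yl ring would keep or lose the step seen here.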